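From compound 3 to compound 4 at the assay limit

The source may report more compounds than this note shows. Statements on the series, on what has been measured and on what is new or still open speak of the compounds shown alone.

In a functional assay on HepG2 cells (Homo sapiens) for cytotoxicity, read by MTT assay, with a stated time of 72 h (a lower number here means a stronger inhibitor, a higher number a weaker inhibitor), compound 3 `CNC(=O)c1cc(Oc2ccc(C3=NN(C(N)=S)C(c4cccc([N+](=O)[O-])c4)C3)cc2)ccn1` gives only a limit, > 50000 nM. Compound 1 `CNC(=O)c1cc(Oc2ccc(C3=NNC(c4ccc([N+](=O)[O-])cc4)C3)cc2)ccn1` likewise gives only a limit, > 50000 nM. Within the data shown here, compound 2 `CNC(=O)c1cc(Oc2ccc(C3=NNC(c4cccc([N+](=O)[O-])c4)C3)cc2)ccn1` is the only one with a number, 26500 nM.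

The next analogue, compound 4 `CNC(=O)c1cc(Oc2ccc(C3=NN(C(N)=S)C(c4ccc(C#N)cc4)C3)cc2)ccn1`, differs from compound 3 in one place: 4-cyanophenyl in place of 3-nitrophenyl on a saturated ring carbon.

Among the measured compounds shown here, two measured steps bear on this change. Placing 3-nitrophenyl where 4-nitrophenyl stood gave an at least 1.8-fold lower number from compound 1 to compound 2 (0.27 log units; that floor lies within the scatter). Adding the group of 3 heavy atoms on the amine nitrogen in the ring gave an at least 1.8-fold higher number from compound 2 to compound 3 (0.27 log units; that floor lies within the scatter), and compound 4 retains that group. Both steps can be read only as floors because of the limit of > 50000 nM in this assay, at which 2 of the 3 values shown sit. For the measured compounds named here, no measured step replaces a nitrophenyl with a cyanophenyl, so no step beyond the scatter is expected in this assay, and neither direction is favoured. The expected step is an at least 1.1-fold lower number from compound 3 to compound 4 (0.04 log units; that floor lies within the scatter). Compound 4 is estimated at 45000 nM, with an expected range of 20000 nM to 100000 nM.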

Compound 4, half-maximal inhibitory concentration: > 50000 nM
Compound 4: a limit, no number (the forecaster's own chance of this, stated with the estimate: 60%); middle value at least 1.1-fold (0.04 log units) from the limit.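

No step can be read between compound 3 and compound 4 in this assay, since each gives only a limit: the limit of > 50000 nM in this assay, at which 3 of the 4 values shown sit.

The compounds shown leave open whether 4-cyanophenyl in place of 3-nitrophenyl changes the read-out in either direction once the number falls within the assay's range.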